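Acetylating the Amino Group of Compound 1

The compounds below may be only part of what the source reports. "The series", "measured", "known", "first", "only" and "open" are said of these compounds alone.

Compound 1 `Cn1nc(N)c2c(=O)[nH]c(-c3ccccc3)cc21` is the reference point for this piece. In an assay on isolated protein for inhibition of ribosomal protein S6 kinase alpha-5 (Homo sapiens), read by mobility shift assay, tested at 30 uM (on this read-out higher numbers stand for more inhibition at the one concentration tested (going by the name of the read-out) and lower numbers for less inhibition), compound 1 gives 9%, the highest of the three numbers in hand, though only one of the gaps to the others is clear. Compound 2 `Cn1nc(N)c2c(=O)[nH]c(-c3ccccn3)cc21` gives -4% in this assay, and the step is a number 13 percentage points lower from compound 1 to compound 2 (beyond the scatter). Compound 3 `COc1cccc(-c2cc3c(c(N)nn3C)c(=O)[nH]2)c1` gives 2% in this assay, and the step is a number 7 percentage points lower from compound 1 to compound 3 (within the scatter). Compound 4 `CC(=O)Nc1nn(C)c2cc(-c3ccccc3)[nH]c(=O)c12` has not yet been measured. It differs from compound 1 by acetyl in place of hydrogen on a nitrogen on an aromatic ring. Neither measured step touches the amino group; both alter the phenyl group, so neither bears directly on this change. Both measured steps were small or within the scatter, and all three values sit near zero, so from compound 1 to compound 4 no step beyond the scatter is expected in this assay. The step expected is a number 4 percentage points lower from compound 1 to compound 4 (within the scatter). Compound 4 is estimated to give 5% in this assay, within a range from -10% to 20%.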

Compound 4, a percentage reported as inhibition, at one concentration (the size of the read-out at that concentration, not a potency): 3%
For compound 4 the middle estimate is 2 percentage points above the measured one; low and high end bracket the measured number.
By their numbers in this assay, from the lowest: compounds 2, 3, 4 and 1 (each within the scatter of the next, the first and the last beyond it).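

Compound 4 is the first change shown at the amino group rather than at the phenyl group, and in this assay the step is a number 6 percentage points lower from compound 1 to compound 4 (within the scatter), so amino to acetamido gives no clear change in this read-out. This is a weak test of the position: compound 1 starts at only 9%, which leaves little room for a loss to show, so the result does not establish that the amino hydrogen is unimportant for inhibition. Nothing at hand explains the result.

Still open, going by these compounds, is whether a benzoyl or methanesulfonyl group on this nitrogen, or a longer chain ending in an amine, would lift the number clearly above that of compound 1. Also open, on these data alone, is whether acetyl would read the same on compound 2 or compound 3.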